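The compounds below may be only part of what the source reports. "The series", "measured", "known", "first", "only" and "open" are said of these compounds alone.

In a functional assay on PC-3 cells (Homo sapiens) for antiproliferative activity, read by MTT assay, with a stated time of 24 h (a higher number here means a weaker inhibitor, a lower number a stronger inhibitor), compound 1 (`COc1ccc(-c2noc(C3CCCN3)n2)cc1OC1CCCC1`) reads > 1000000 nM as a limit of the assay, not a number. Compound 2 (`COc1ccc(-c2noc(-c3cccnc3)n2)cc1OC1CCCC1`) likewise gives > 1000000 nM as a limit only. Going by the values given here, compound 3 (`COc1ccc(-c2noc(-c3ccc(O)cc3)n2)cc1OC1CCCC1`) gives 162000 nM in this assay and holds the only number of the set. The other two readings define the ceiling of the series (the limit of > 1000000 nM in this assay, at which 2 of the 3 values shown sit), so compound 3 has no numeric neighbour to be ranked against.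

Compound 4 (`COc1ccc(-c2noc(-c3ccc(Cl)cc3)n2)cc1OC1CCCC1`) carries chloro in place of hydroxy on an aromatic carbon, para to a large group (chloro in place of hydroxy on an aromatic carbon). Among the compounds with values here, two measured steps bear on this: (an at least 6.1-fold lower number from compound 1 to compound 3 (0.79 log units; beyond the scatter)) and (an at least 6.1-fold lower number from compound 2 to compound 3 (0.79 log units; beyond the scatter)), each with 4-hydroxyphenyl entering. The remaining step (a step that the two limits leave unreadable from compound 1 to compound 2) gives no size. Neither readable step isolates the hydroxy, as each replaces the whole group, and compound 4 keeps the ring of compound 3 while only the hydroxy goes. A change beyond the scatter is therefore not expected, in either direction, from the anchor of compound 3 at 162000 nM in this assay. A reading at the limit remains possible for compound 4. The expected outcome is a 1.1-fold lower number from compound 3 to compound 4 (0.03 log units; within the scatter) on present evidence. For compound 4 the estimated value is 150000 nM with an expected range of 40000 nM to 600000 nM for now.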

Compound 4, half-maximal inhibitory concentration: > 1000000 nM
Compound 4: no number, only a limit; the forecaster's own chance of this, stated with the estimate: 30%; middle value at least 6.6-fold (0.82 log units) away from the limit.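

In this assay, chloro in place of hydroxy on an aromatic carbon, para to a large group, gives an at least 6.1-fold higher number from compound 3 to compound 4 (0.79 log units; beyond the scatter), and since the six-membered aromatic ring stays, this step isolates the hydroxy in a way the earlier whole-group replacements could not. The aromatic ring alone therefore does not secure a numeric reading: compound 3 and compound 4 both carry it, and only the 4-hydroxyphenyl compound gives a number, while the limit reached by compound 4 gives the true size of the step only as a bound. The steps from compound 1 and from compound 2 to compound 4 cannot be read, and compound 3 remains the only compound with a number, set against a shared ceiling: the limit of > 1000000 nM in this assay, at which 3 of the 4 values shown sit.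

Whether the hydroxy itself is required at this place stays open, as the compounds shown do not include a methoxy, an amine or a carboxylic acid there. Also open, on these data alone, is whether a numeric reading at this place would hold up with any change to the rest of the shared core, which is the same in all four compounds.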